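Para Trifluoromethyl on the Benzylsulfanyl Arm of Compound 1

The source may hold more compounds than are shown below. What is called first, only, known or untested is meant among the compounds shown, and "the series" means these compounds.

Within the data shown here, compound 1 `Cc1cc(N2CC[C@@H](C)[C@@H](N(C)c3ncnc4[nH]ccc34)C2)n2nc(SCc3ccccc3)nc2n1` is one of three compounds measured in a functional assay on HGC-27 cells (Homo sapiens) for inhibition, read by MTT assay, with a stated time of 72 h (on this read-out lower numbers stand for stronger inhibition and higher numbers for weaker inhibition), where compound 1 gives 13900 nM, the lowest of the three numbers; both neighbours sit within the scatter of it. Compound 2 `Cc1cc(N2CC[C@@H](C)[C@@H](N(C)c3ncnc4[nH]ccc34)C2)n2nc(SCc3ccc(F)cc3)nc2n1` gives 26000 nM in this assay, and compound 3 `Cc1cc(N2CC[C@@H](C)[C@@H](N(C)c3ncnc4[nH]ccc34)C2)n2nc(SCc3ccc(Br)cc3)nc2n1` gives 19500 nM. The steps are small: a 1.9-fold higher number from compound 1 to compound 2 (0.27 log units; within the scatter), a 1.4-fold higher number from compound 1 to compound 3 (0.15 log units; within the scatter) and a 1.3-fold lower number from compound 2 to compound 3 (0.12 log units; within the scatter), none of them beyond the scatter.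

Compound 4 `Cc1cc(N2CC[C@@H](C)[C@@H](N(C)c3ncnc4[nH]ccc34)C2)n2nc(SCc3ccc(C(F)(F)F)cc3)nc2n1` has not yet been measured. It differs from compound 1 in one place: trifluoromethyl in place of hydrogen on an aromatic carbon, on an aromatic carbon of a six-membered aromatic ring of carbon only, para to a large group. The two measured steps from compound 1 bear on this change, since each also puts a group on that same aromatic carbon, and both gave only small, within-scatter movements toward higher numbers.

Compound 4 is therefore expected to stay close to compound 1 in this assay, with at most a modest drift to a higher number, as a 1.4-fold higher number from compound 1 to compound 4 (0.16 log units; within the scatter). The estimate for compound 4 is 20000 nM, with a range from 8000 nM to 50000 nM.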

Compound 4, half-maximal inhibitory concentration: 9540 nM
Estimate against measurement, compound 4: 2.1-fold (0.32 log units) above, and the stated range covers the measured number.
By their numbers in this assay, from the lowest: compounds 4, 1, 3 and 2 (each within the scatter of the next, the first and the last beyond it).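

In this assay, trifluoromethyl on this aromatic carbon, para to a large group, gives a 1.5-fold lower number from compound 1 to compound 4 (0.16 log units; within the scatter), so a group of 4 heavy atoms can stand here without moving the number beyond the scatter from that of the unsubstituted benzyl compound. Among these compounds, the result also separates the groups at this carbon for the first time: no pair among compounds 1, 2 and 3 lay beyond the scatter, whereas a 2.0-fold lower number from compound 3 to compound 4 (0.31 log units; beyond the scatter) and a 2.7-fold lower number from compound 2 to compound 4 (0.44 log units; beyond the scatter) both do, though only modestly, and compound 1 remains within the scatter of compound 4. No measurement shown here explains why trifluoromethyl parts from bromo and fluoro at this carbon.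

The compounds shown carry only halogen-containing groups at this one place, so it remains open whether an amine, a carboxylic acid or a longer chain would stay within the same narrow band in this assay. From the compounds shown here alone, it is also open whether trifluoromethyl would give the same result on the other carbons of the phenyl ring, or whether these modest gaps would hold on a different core.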